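The compounds below may be only part of what the source reports. "The series", "measured", "known", "first", "only" and "open" are said of these compounds alone.

In a functional assay on NUGC-3 cells (Homo sapiens) for antiproliferative activity, read by sulforhodamine B assay (a lower number here means a stronger inhibitor of growth, a higher number a weaker inhibitor of growth), compound 1 `CC(C)CCCOc1cccc(O)c1C(=O)/C=C/c1ccc(O)cc1` gives 3520 nM, and compound 2 `CC(C)(C)CCOc1cccc(O)c1C(=O)/C=C/c1ccc(C(=O)O)cc1` gives 5440 nM. Compound 3 `O=C(/C=C/c1ccc(O)cc1)c1c(O)cccc1OCCC1CCCCC1` reads > 30000 nM, which is a limit of the assay and not a number. Compound 4 `O=C(/C=C/c1ccc(O)cc1)c1c(O)cccc1OCc1ccccc1` differs from it in one place: phenyl in place of cyclohexylmethyl on a saturated chain carbon bound to an oxygen on an aromatic ring, so the carbon ring on the chain becomes aromatic. Among the compounds with values here, one measured step bears on this, the swap of cyclohexyl in place of isobutyl, which gave an at least 8.5-fold higher number from compound 1 to compound 3 (0.93 log units; beyond the scatter). That step shows that this chain can shift the number well beyond the scatter, so removing the cyclohexyl is expected to lower it in this assay. The expected change is an at least 2.5-fold lower number from compound 3 to compound 4 (0.39 log units; beyond the scatter), though only loosely, and the limit could recur. For compound 4 the estimate is 12000 nM, with an expected range of 3000 nM to 40000 nM.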

Compound 4, concentration for 50% growth inhibition: > 30000 nM
Compound 4: no number, only a limit (the forecaster's own chance of this, stated with the estimate: 35%); middle value at least 2.5-fold (0.39 log units) away from the limit.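

In this assay compound 4 gives > 30000 nM, a limit of the assay and not a number, so its step from compound 3 cannot be read. Replacing the isopentyl chain with phenyl still gives an at least 8.5-fold higher number from compound 1 to compound 4 (0.93 log units; beyond the scatter), so the aromatic ring does not recover the growth inhibition lost with the cyclohexyl ring. Both ring-bearing chains end at the same ceiling: the limit of > 30000 nM in this assay, at which 2 of the 4 values shown sit.

Going by these compounds, how far compound 3 and compound 4 truly differ remains unknown, so their rings cannot be ranked. On these data alone, whether an amine on this chain would restore activity also stays open.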